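Amide-ring swap on a shared benzoxazolylthio propanamide core

This account rests on a few compounds, and the source may have more. Where it says the series, first, only, none or still open, it means among the compounds named here.

Measured compounds:
compound 1 `O=C(CCSc1nc2cc(Cl)ccc2o1)NC1CCCC1`: 11.3 mL/min/g
compound 2 `CC1CCN(C(=O)CCSc2nc3cc(Cl)ccc3o2)C1`: 10.1 mL/min/g

In an ADME assay on microsomes from liver (Homo sapiens) for metabolic stability, read by LC-MS, using NADPH, with a stated time of 45 min, tested at 0.5 uM (a higher number here means faster removal of the compound, a lower number slower removal), compound 2 gives the lowest of the two numbers; its nearest neighbour is compound 1, and the step of a 1.1-fold lower number from compound 1 to compound 2 (0.05 log units; within the scatter) lies within the scatter. Compound 3 `O=C(CCSc1nc2cc(Cl)ccc2o1)N1CCS(=O)(=O)C1` has not yet been measured. It differs from compound 2 by 1,1-dioxo-1,3-thiazolidin-3-yl in place of 3-methylpyrrolidin-1-yl on a carbonyl carbon. Among the measured compounds shown here, the one measured step, at the same carbonyl carbon, was a 1.1-fold lower number from compound 1 to compound 2 (0.05 log units; within the scatter), so no step beyond the scatter is expected for a 1.1-fold lower number from compound 2 to compound 3 (0.05 log units; within the scatter). Compound 3 is therefore estimated at 9 mL/min/g, within 4.5 mL/min/g to 18 mL/min/g.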

Compound 3, intrinsic clearance in a liver preparation (reported as CLH), per the amount of preparation that the assay uses: 1.7 mL/min/g
For compound 3 the middle estimate is 5.3-fold (0.72 log units) above the measured one; the measured number lies below the stated range.
By their numbers in this assay, from the lowest: compound 3; then compounds 2 and 1 (each within the scatter of the next).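

The carbonyl carbon had shown no step beyond the scatter, but in this assay this position proves able to change the number: 1,1-dioxo-1,3-thiazolidin-3-yl in place of 3-methylpyrrolidin-1-yl gives a clear drop (a 5.9-fold lower number from compound 2 to compound 3 (0.77 log units; beyond the scatter)). The drop is of similar size against cyclopentylamino (a 6.6-fold lower number from compound 1 to compound 3 (0.82 log units; beyond the scatter)), so compound 3 stands apart from both earlier compounds. Nothing available here accounts for this.

The compounds shown leave open whether the ring sulfur or its two oxygens carry the step, which a plain 1,3-thiazolidin-3-yl would test. They also leave open whether the six-membered 1,1-dioxothiomorpholin-4-yl would behave alike.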